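Adding one methoxy group to compound 3

The compounds below may be only part of what the source reports. "The series", "measured", "known", "first", "only" and "open" are said of these compounds alone.

In a functional assay on HepG2 cells (Homo sapiens) for antiproliferative activity, read by sulforhodamine B assay, with a stated time of 48 h (on this read-out lower numbers stand for stronger inhibition and higher numbers for weaker inhibition), compound 1 (`COc1ccc(/C=C/C(=O)c2ccccc2-c2cc(OC)c(OC)c(OC)c2)cc1O`) gives 190 nM and compound 2 (`COc1ccc(C(=O)/C=C/c2ccccc2-c2ccc(F)cc2)cc1`) gives 6300 nM. Compound 3 (`COc1ccc(C(=O)/C=C/c2ccccc2-c2ccc(F)nc2)cc1`) gives 8200 nM, which is level with compound 2 within the scatter and far above compound 1. Compound 4 (`COc1ccc(C(=O)/C=C/c2ccccc2-c2ccc(F)nc2)cc1OC`) differs from compound 3 by one change: methoxy in place of hydrogen on an aromatic carbon. Within the data shown here, the only measured single change, a 1.3-fold higher number from compound 2 to compound 3 (0.11 log units; within the scatter), involves a different group and stays within the scatter. Among the measured compounds shown here, no measured step tests this methoxy, so no clear shift in either direction is expected. The estimated step is a 1.3-fold lower number from compound 3 to compound 4 (0.10 log units; within the scatter). For compound 4 the expected value is 6500 nM, with an estimated range of 2000 nM to 20000 nM.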

Compound 4, half-maximal inhibitory concentration: 17000 nM
The estimate for compound 4 lay 2.6-fold (0.42 log units) below the measured number, within the range that was stated.
By their numbers in this assay, from the lowest: compound 1; then compounds 2 and 3 (each within the scatter of the next); then compound 4.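

Putting methoxy in place of hydrogen, ortho to a methoxy group and meta to a large group, gives in this assay a 2.1-fold higher number from compound 3 to compound 4 (0.32 log units; beyond the scatter) as the first single change shown to pass beyond the scatter. Its direction is toward weaker inhibition, though the shift is modest. Nothing available accounts for this shift.

As far as these compounds go, whether any group at this position would weaken inhibition, or only methoxy, remains open. An amine or a longer chain such as ethoxy on the same carbon could separate those two readings.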